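The compounds below may be only part of what the source reports. "The series", "measured", "known", "first", "only" and "open" are said of these compounds alone.

Compound 2, with the structure `NC(=O)c1c(NC(=O)c2ccccc2C(F)(F)F)sc2c1CCN(C(=S)Nc1ccccc1Br)C2`, carries a bromo group on the aryl ring attached to its thiourea and a trifluoromethyl group on its benzamide. In a functional assay on HeLa cells (Homo sapiens) for antiproliferative activity, with a stated time of 24 h (on this read-out higher numbers stand for weaker inhibition and lower numbers for stronger inhibition), compound 2 gives > 50000 nM, which is a limit of the assay rather than a measured number. Compound 1, with the structure `Cc1ccccc1NC(=S)N1CCc2c(sc(NC(=O)c3ccccc3Cl)c2C(N)=O)C1`, shares the same core. In this assay compound 1 gives > 50000 nM, again a limit. Both values shown therefore sit at the same edge of what the assay can report, as noted in the limit of > 50000 nM in this assay, at which 2 of the 2 values shown sit.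

Compound 3, with the structure `Cc1ccccc1NC(=S)N1CCc2c(sc(NC(=O)c3ccccc3C(F)(F)F)c2C(N)=O)C1`, has not yet been measured. It differs from compound 2 in one place: methyl in place of bromo on an aromatic carbon. Going by the values given here, no step between two measured compounds is available for this change. With both measured compounds at the limit, a step from compound 2 to compound 3 of no size beyond the scatter is expected in this assay, that is a number no higher from compound 2 to compound 3 (the limit leaves the size open). Compound 3 is accordingly expected to give about 50000 nM in this assay, within a range from 20000 nM to 50000 nM, and most likely to be reported only as a limit.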

Compound 3, half-maximal inhibitory concentration: 47000 nM
The estimate for compound 3 lay 1.1-fold (0.03 log units) above the measured number, and the stated range covers the measured number.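

In this assay, going by these compounds alone, compound 3 gives 47000 nM, the only one of the three values shown that is a measured number rather than a limit, so this family of compounds can register on the read-out. Methyl in place of bromo on an aromatic carbon gives an at least 1.0-fold lower number from compound 2 to compound 3 (0.02 log units; that floor lies within the scatter), and the swap of chloro for trifluoromethyl on the benzamide gives an at least 1.0-fold lower number from compound 1 to compound 3 (0.02 log units; that floor lies within the scatter). Each step starts from a limit and gives only a floor, so the true size of either change stays unknown, and the number for compound 3 lies close to the edge of what can be reported: the limit of > 50000 nM in this assay, at which 2 of the 3 values shown sit.

The compounds shown leave open whether methyl on the aryl ring of the thiourea, trifluoromethyl on the benzamide, or the two together account for the measured number in compound 3. They also do not tell what an amine, a hydroxyl or a methoxy group on the same aromatic carbon would give, or whether any such group would bring the number well clear of the limit.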